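Adding allylsulfanyl to the shared core: working notes

The source may report more compounds than this note shows. Statements on the series, on what has been measured and on what is new or still open speak of the compounds shown alone.

In an ADME assay on WI-38 cells (Homo sapiens) for antiproliferative activity, read by sulforhodamine B assay, with a stated time of 72 h (on this read-out higher numbers stand for weaker inhibition and lower numbers for stronger inhibition), compound 1 (`C=CCOC(=O)C1=C2C(=NC1=O)c1cccc3cccc2c13`) gives 20600 nM and compound 2 (`CCCSC(=O)COC(=O)C1=C2C(=NC1=O)c1cccc3cccc2c13`) gives 25200 nM. Among the measured compounds shown here, these two values lie within the scatter of each other, so compound 2 stands level with the only other measured compound. Compound 3 (`C=CCSc1ccc2c3c(cccc13)C1=NC(=O)C(C(=O)OCC(=O)SCCC)=C12`) keeps the side chain of compound 2 and carries allylsulfanyl in place of hydrogen on an aromatic carbon.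

For the measured compounds named here, the one measured step, a 1.2-fold higher number from compound 1 to compound 2 (0.09 log units; within the scatter), exchanges vinyl for (propylsulfanyl)carbonyl on the side chain and stays within the scatter. It bears on the new change only indirectly, since it concerns a different place. Going by the values given here, no measured compound carries a substituent on this aromatic carbon, so the data give no direction for the change. A step beyond the scatter in this assay is therefore not expected, although the uncertainty is wide. The expected step is a 1.4-fold lower number from compound 2 to compound 3 (0.15 log units; within the scatter). Compound 3 is estimated at 18000 nM, with an expected range of 6000 nM to 50000 nM.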

Compound 3, half-maximal inhibitory concentration: > 100000 nM
Compound 3: only a limit was reported; the forecaster's own chance of this, stated with the estimate: 10%; at least 5.5-fold (0.74 log units) between middle value and limit.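

Compound 3 is the first compound here with a substituent on this aromatic carbon, and in this assay it is reported only as a limit: the limit of > 100000 nM in this assay, at which 1 of the 3 values shown sits.

Allylsulfanyl in place of hydrogen at this carbon gives an at least 3.9-fold higher number from compound 2 to compound 3 (0.59 log units; beyond the scatter), so this position, on the six-membered aromatic ring of the shared core, moves the read-out beyond the scatter and towards weaker inhibition, whereas the side chain exchange gave only a 1.2-fold higher number from compound 1 to compound 2 (0.09 log units; within the scatter) and stayed within it. On these data alone, the step fixes a lower bound and a direction for this one group on this one side chain, and its full size remains unknown.

As far as these compounds go, whether the step belongs to allylsulfanyl as a whole, to its sulfur or to its double bond stays open, as does whether an amine, a carboxylic acid or a longer saturated chain on the same carbon would shift the read-out in the same direction. Among the compounds shown here, also open is whether allylsulfanyl at this carbon would give a similar step with the side chain of compound 1 in place of the one carried by compound 2.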